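The source may report more compounds than this note shows. Statements on the series, on what has been measured and on what is new or still open speak of the compounds shown alone.

Two compounds that share a core and differ in where the acetyl and the two aryl groups sit have been measured in a functional assay on MCF7 cells (Homo sapiens) for cytotoxicity, read by MTT assay, with a stated time of 2 days, tested at 1 uM; a lower number here means a stronger effect, a higher number a weaker effect of the compound at the concentration tested. Compound 1 `COc1ccc(-c2cc(C(C)=O)c3[nH]c(-c4ccc(F)cc4)cc3c2)cc1` gives 69.7% in this assay. Compound 2 `COc1ccc(-c2cc3cc(-c4ccc(F)cc4)cc(C(C)=O)c3[nH]2)cc1` gives 96.4% in this assay, the highest of the two numbers and therefore the weaker effect at the concentration tested; the number for compound 1 lies beyond the usual scatter below it.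

Compound 3 `COc1ccc(-c2cc(C(C)=O)c3[nH]c(-c4ccc(OC)cc4)cc3c2)cc1` keeps everything of compound 2 except one group on the outer ring: methoxy in place of fluoro on an aromatic carbon. The methoxy that enters sits on an aromatic carbon of a six-membered aromatic ring of carbon only, in the position the fluoro occupied. Among the measured compounds shown here, no measured pair shows what exchanging fluoro for methoxy does here, so the expectation can rest only on the weak effect of compound 2 at 96.4%. A small step is expected, a number 6.4 percentage points lower from compound 2 to compound 3 (within the scatter), most likely not beyond the scatter, with a slight lean toward a stronger effect. Compound 3 is therefore expected to give about 90% in this assay, within a range from 70% to 105%.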

Compound 3, a percentage reported as activity, at one concentration (the size of the read-out at that concentration, not a potency): 62.6%
For compound 3 the middle estimate is 27.4 percentage points above the measured one; measured number below the stated range.
By their numbers in this assay, from the lowest: compounds 3 and 1 (each within the scatter of the next); then compound 2.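

In this assay, the exchange of fluoro for methoxy turns out to depend on which of the two outer rings carries it. On the ring that holds the fluoro in compound 2, the exchange gives a number 33.8 percentage points lower from compound 2 to compound 3 (beyond the scatter), whereas on the ring that holds the fluoro in compound 1, it gives a number 7.1 percentage points lower from compound 1 to compound 3 (within the scatter), so at that second ring no real change can be told from ordinary assay noise. Nothing here explains why the two rings respond so differently.

Among the compounds shown here, only two groups have been compared at these positions, so it remains open whether the large step reflects something gained with methoxy or something lost with fluoro; a plain hydrogen, a chlorine, a hydroxyl, an amine or a longer ethoxy chain on the sensitive ring would help separate the two. From the compounds shown here alone, each number is also a read-out at a single concentration, so it shows only a stronger or weaker effect at that concentration, and how these compounds compare at other concentrations remains unknown.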